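The source may report more compounds than this note shows. Statements on the series, on what has been measured and on what is new or still open speak of the compounds shown alone.

Compound 1 `CC1SC(c2cccc(C(=O)NCCCCc3ccccc3)c2)N(c2ccc(C3CC3)cc2)C1=O` is the starting point. In a physicochemical assay for solubility, read by turbidimetry, measured as kinetic solubility, at pH 6.8 (a higher number here means a more soluble compound, a lower number a less soluble compound), compound 1 gives 10000 nM. Compound 2 `COc1ccccc1N1C(=O)CSC1c1cc(F)cc(C(=O)NCCCCc2ccccc2)c1` gives 10000 nM in this assay, level with compound 1 at the digits recorded and within the scatter, so the two together are the lowest numbers of the three. Compound 3 `O=C(NCCCCn1cccn1)c1cccc(C2SCC(=O)N2c2cc(F)ccn2)c1` gives 50000 nM, a higher number than compound 1 by a margin beyond the scatter. Compound 4 `O=C(NCCCCc1ccccc1)c1cccc(C2SCC(=O)N2c2ccc(C3CC3)cc2)c1` has not been measured in this assay. It differs from compound 1 by hydrogen in place of methyl on a saturated ring carbon. For the measured compounds named here, no measured pair isolates this change, so the size of its step can only be estimated. The author expects the step of a 1.2-fold higher number from compound 1 to compound 4 (0.08 log units; within the scatter) to stay within the scatter or to rise only slightly. For compound 4 the estimate is 12000 nM, ranging from 5000 nM to 30000 nM.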

Compound 4, solubility: 2000 nM
The estimate for compound 4 lay 6.0-fold (0.78 log units) above the measured number, outside the stated range (below it).
By their numbers in this assay, from the lowest: compound 4; then compounds 1 and 2 (each within the scatter of the next); then compound 3.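

Hydrogen in place of methyl on the saturated ring carbon next to the ring sulfur gives a 5.0-fold lower number from compound 1 to compound 4 (0.70 log units; beyond the scatter) in this assay and so lies beyond the scatter. For the compounds shown here, this is the first pair differing in one place, and it shows that this single carbon can move the number on its own, with the methyl compound reading higher. No supporting data bear on why the number moves.

On these data alone, whether the step carries over to the different groups of compounds 2 and 3 stays open. So does what an ethyl or a hydroxymethyl group on this carbon would give.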